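The source may hold more compounds than are shown below. What is called first, only, known or untested is meant among the compounds shown, and "the series" means these compounds.

Measured compounds:
- compound 1 `CC(=O)OCC(CCn1cc(C#CC2CC2)c(=O)n(C(=O)c2ccccc2)c1=O)COC(C)=O`: 100 nM
- compound 2 `CCCCCC#Cc1cn(CCC(COC(C)=O)COC(C)=O)c(=O)n(C(=O)c2ccccc2)c1=O`: 62200 nM
- compound 3 `O=c1[nH]c(=O)n(CCC(CO)CO)cc1C#CC1CC1`: > 100000 nM

All three were tested in a functional assay on MCF7 cells (Homo sapiens) for antiproliferative activity, read by MTT assay, with a stated time of 72 h; on this read-out higher numbers stand for weaker inhibition and lower numbers for stronger inhibition. Compound 1 gives 100 nM in this assay. Compound 2 differs from compound 1 in one place: pentyl in place of cyclopropyl on a triple-bonded carbon. That single change brings a 620-fold higher number from compound 1 to compound 2 (2.79 log units; beyond the scatter), so the pentyl analogue inhibits growth far more weakly than the cyclopropyl one.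

Compound 3 carries the cyclopropyl group on a different core, with free hydroxyl groups and an unprotected ring nitrogen in place of the acetyl and benzoyl groups of compound 1; the difference between the two cores is not broken down here. In this assay compound 3 reaches only a limit, > 100000 nM, which is the upper end of what the assay reports rather than a measured number (the limit of > 100000 nM in this assay, at which 1 of the 3 values shown sits).

Compound 4 `CCCCCC#Cc1cn(CCC(CO)CO)c(=O)[nH]c1=O` is not yet measured. It stands to compound 3 as compound 2 stands to compound 1: pentyl in place of cyclopropyl on a triple-bonded carbon. Since the place of the change is described in the same words in both pairs, this is the same change. In the measured pair it made inhibition much weaker; compound 3 already sits at the limit of the assay. The step from compound 3 to compound 4 is therefore expected to be a step that the limit leaves unreadable from compound 3 to compound 4, pointing the same way, but likely hidden by the limit. Compound 4 is estimated at 500000 nM in this assay, within 100000 nM to 3000000 nM.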

Compound 4, half-maximal inhibitory concentration: 37800 nM
Compound 4: the middle estimate sits 13-fold (1.12 log units) above what was measured; measured number below the stated range.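

In this assay, pentyl in place of cyclopropyl on a triple-bonded carbon does not carry over from one core to the other, and the two steps run in opposite directions: the same change on two cores in this assay, a 620-fold higher number (2.79 log units; beyond the scatter) from compound 1 to compound 2 and an at least 2.6-fold lower number (0.42 log units; beyond the scatter) from compound 3 to compound 4, at least 1600-fold (3.21 log units) apart, beyond the scatter of two such steps

On the core of compound 3, this change brings an at least 2.6-fold lower number from compound 3 to compound 4 (0.42 log units; beyond the scatter), so the pentyl compound is the stronger inhibitor of the pair, whereas on the core of compound 1 the cyclopropyl compound is the stronger one. Compound 3 has only a limit of the assay and not a measured number, so the direction of this step can be read but its true size cannot: the limit of > 100000 nM in this assay, at which 1 of the 4 values shown sits.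

The two cores differ in their acetyl and benzoyl groups as well as in their free hydroxyl groups and unprotected ring nitrogen, and the compounds shown leave open which of these differences decides how the change turns out. Also open, going by these compounds, is how a longer chain than pentyl, or an amine at the end of the chain, would fare on each core.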